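This account rests on a few compounds, and the source may have more. Where it says the series, first, only, none or still open, it means among the compounds named here.

Three compounds share one core and were tested in an assay on isolated protein for inhibition of ubiquitin carboxyl-terminal hydrolase 47 (Homo sapiens); a higher number here means a weaker inhibitor, a lower number a stronger inhibitor: compound 1 `Nc1cc(-c2cc(Cl)cc3c2OC(C(=O)N2CCNCC2)C3)ccn1`, compound 2 `O=C([C@H]1Cc2cc(Cl)cc(-c3ccnc4[nH]ccc34)c2O1)N1CCNCC1` and compound 3 `Cc1cc2nccc(-c3cc(Cl)cc4c3O[C@@H](C(=O)N3CCNCC3)C4)c2s1`. For compound 1 the result is only a limit of the assay, > 80000 nM. For compound 2 the result is likewise a limit, > 80000 nM. For compound 3 the result is again a limit, > 80000 nM. Within the data shown here, compound 3 thus stands where every measured compound here stands, at the limit of > 80000 nM in this assay, at which 3 of the 3 values shown sit; no number separates it from compound 1 or compound 2, and no step between measured compounds can be read off.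

Compound 4 `O=C([C@H]1Cc2cc(Cl)cc(-c3ccnc4cc(Cn5cnccc5=O)sc34)c2O1)N1CCNCC1` is not yet measured in this assay. It differs from compound 3 in one place: a group of 7 heavy atoms (4 carbon, 2 nitrogen, 1 oxygen; one six-membered aromatic ring with 2 hetero atoms) in place of a hydrogen atom, on a saturated chain carbon bound to an aromatic carbon.

Among the measured compounds shown here, with no measured step to lean on, the size of the change from compound 3 to compound 4 cannot be read from earlier pairs; any guess rests on the structural change alone. The step is expected to run toward a stronger inhibitor, an at least 1.6-fold lower number from compound 3 to compound 4 (0.20 log units; that floor lies within the scatter), though its true size is uncertain because compound 3 sits only at the limit of > 80000 nM in this assay, at which 3 of the 3 values shown sit. Compound 4 is therefore expected to give about 50000 nM in this assay, within 5000 nM to 200000 nM, with a real chance that the assay again returns only a limit.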

Compound 4, half-maximal inhibitory concentration: > 5000 nM
Compound 4 gave a limit, no number (the forecaster's own chance of this, stated with the estimate: 65%); the middle value is on the limit's open side.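

Among these compounds, compound 3 and compound 4 both return only limits in this assay, not numbers, so no step between them can be read. The compounds shown leave open whether putting the new group, with its six-membered aromatic ring, on that saturated chain carbon changes inhibition at all, and how strongly any of the four compounds actually inhibits.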